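From allyl to 2-formylethyl: what compound 3 may show

This account rests on a few compounds, and the source may have more. Where it says the series, first, only, none or still open, it means among the compounds named here.

Measured in a functional assay on HCT-116 cells (Homo sapiens) for cytotoxicity, read by MTT assay, with a stated time of 72 h; a higher number here means a weaker inhibitor, a lower number a stronger inhibitor:
- Compound 1 `COc1ccc(-c2cc3ccc(OC)c(OC)c3c(=O)[nH]2)cc1OC` gives > 10000 nM (a limit)
- Compound 2 `C=CCn1c(-c2ccc(OC)c(OC)c2)cc2ccc(OC)c(OC)c2c1=O` gives > 10000 nM (a limit)

In this assay compound 2 gives > 10000 nM and this is a limit of the assay, not a number.

Compound 3 `COc1ccc(-c2cc3ccc(OC)c(OC)c3c(=O)n2CCC=O)cc1OC` keeps the shared core. In it, formylmethyl takes the place of vinyl on a saturated chain carbon bound to an aromatic nitrogen (formylmethyl in place of vinyl on a saturated chain carbon bound to an aromatic nitrogen), which can also be read as allyl to 2-formylethyl.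

Within the data shown here, the only measured step that bears on this is a step that the two limits leave unreadable from compound 1 to compound 2 and it offers no size to carry over. The evidence is thin: the limit of > 10000 nM in this assay, at which 2 of the 2 values shown sit, is all there is. No step beyond the scatter can be supported, so the assay may again report only a limit.

The estimated step is a step that the limit leaves unreadable from compound 2 to compound 3 in this assay and it is only an expectation. Compound 3 is expected at about 12000 nM (estimated range 3000 nM to 40000 nM).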

Compound 3, half-maximal inhibitory concentration: > 10000 nM
Compound 3: only a limit was reported; the forecaster's own chance of this, stated with the estimate: 70%; the middle value is on the limit's open side.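

No step can be read between compound 1, compound 2 and compound 3 in this assay, because each result is only a limit, not a number: the limit of > 10000 nM in this assay, at which 3 of the 3 values shown sit.

The compounds shown leave open whether hydrogen, allyl or 2-formylethyl on an aromatic nitrogen makes any difference to the cytotoxicity.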